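The source may report more compounds than this note shows. Statements on the series, on what has been measured and on what is new or still open speak of the compounds shown alone.

Compound 1 `COc1ccc(C2N=C(SCc3ccccc3)NC(C)=C2C(=O)Nc2ccc(Br)cc2)cc1` was tested in a functional assay on the whole organism (artery, strain albino) with Rattus norvegicus as the target, with a stated time of 30 min, at a dose of 10 mg/kg by the oral route (on this read-out lower numbers stand for less inhibition and higher numbers for more inhibition at the one dose given (going by the name of the read-out)), where compound 1 gives 2.6%. Compound 2 `COc1ccc(C2N=C(SCc3ccc(Cl)cc3)NC(C)=C2C(=O)Nc2ccc(Br)cc2)cc1` differs from compound 1 only by chloro in place of hydrogen on an aromatic carbon; in this assay compound 2 gives 7.2%, which is a step of a number 4.6 percentage points higher from compound 1 to compound 2 (within the scatter). Compound 3 `CC1=C(C(=O)Nc2ccc([N+](=O)[O-])cc2)C(c2ccc(Br)cc2)N=C(SCc2ccccc2)N1` carries a different core, and the difference between the two cores is not broken down here. In this assay compound 3 gives 3.6%. All three numbers lie within the usual scatter of one another, so none of them can be ranked against the others.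

Compound 4 `CC1=C(C(=O)Nc2ccc([N+](=O)[O-])cc2)C(c2ccc(Br)cc2)N=C(SCc2ccccc2Cl)N1` has not yet been measured. It differs from compound 3 by chloro in place of hydrogen on an aromatic carbon. Among the measured compounds shown here, this is the same kind of change as the one from compound 1 to compound 2, but not the same change: in compound 2 the chloro sits para to a large group, whereas in compound 4 it sits ortho to a large group. A step of about a number 3.4 percentage points higher from compound 3 to compound 4 (within the scatter) is expected, and this expectation rests on the small step of a number 4.6 percentage points higher from compound 1 to compound 2 (within the scatter). Compound 4 is therefore expected to give about 7% in this assay, most likely between 0% and 17%.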

Compound 4, a percentage reported as inhibition, in the whole organism at one dose (the size of the read-out at that dose, not a potency): 3.6%
Compound 4: middle estimate off by 3.4 percentage points, on the high side; measured number inside the range.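

In this assay, the swap of benzyl for 2-chlorobenzyl gives no change at the digits printed from compound 3 to compound 4 (within the scatter). Set beside the earlier step, the chloro change looks no different on the two cores: the same change on two cores in this assay, a number 4.6 percentage points higher (within the scatter) from compound 1 to compound 2 and no change at the digits printed (within the scatter) from compound 3 to compound 4, 4.6 percentage points apart, within the scatter of two such steps. Among the compounds shown here, this agrees with the change carrying over from one core to the other, but it does not prove that it does: neither step stands out from the scatter, so there is no clear effect to carry, and the chloro in compound 4 sits ortho to a large group, a different place from the one it holds in compound 2.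

The compounds shown leave open whether the chloro would behave alike on the two cores if it held the same place on the ring in both. They also leave open whether a larger change at this end of the molecule, such as an amine or a carboxylic acid on the benzyl ring or a longer chain in place of the benzyl, would move the number beyond the scatter.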